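The source may hold more compounds than are shown below. What is called first, only, known or untested is meant among the compounds shown, and "the series" means these compounds.

Compound 2, `CCOC(CCn1c(Cc2nn(C)c(=O)c3ccccc23)nnc1SCCCCCCCC(=O)Nc1ccc(Cl)cc1Cl)OCC`, gives 16400 nM in an assay on 32D cells for inhibition of interleukin-15 (Mus musculus), read by resazurin assay, with stated times of 30 min and 2.5 days, in the presence of a further agent that is not named here (a lower number here means a stronger inhibitor, a higher number a weaker inhibitor), the highest of the three numbers recorded. Compound 1, `Cn1c(Cc2nn(C)c(=O)c3ccccc23)nnc1SCCCCCCCC(=O)Nc1ccc(Cl)cc1Cl`, gives 3900 nM in this assay, and compound 3, `Cn1nc(Cc2nnc(SCC(=O)Nc3ccc(Cl)cc3Cl)n2CCC=O)c2ccccc2c1=O`, gives 6400 nM, so compound 2 sits beyond the scatter above both.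

Compound 4, `Cn1nc(Cc2nnc(SCCCCCCCC(=O)Nc3ccc(Cl)cc3Cl)n2CCC=O)c2ccccc2c1=O`, differs from compound 2 by formyl in place of diethoxymethyl on a saturated chain carbon, two bonds along the chain from an aromatic nitrogen, that is, by 3,3-diethoxypropyl giving way to 2-formylethyl on the chain attached to the aromatic nitrogen of the shared core. Going by the values given here, the only measured step that touches this region of the molecule is a 4.2-fold higher number from compound 1 to compound 2 (0.62 log units; beyond the scatter), which shows that attaching the 2,2-diethoxyethyl group cost potency. Compound 3 carries the same 2-formylethyl chain as compound 4 but with a shorter linker to the dichlorophenyl amide. In this assay compound 3 gives 6400 nM, which falls between the values of compound 1 and compound 2. Removing the diethoxymethyl portion is therefore expected to recover part of the loss seen in the step from compound 1 to compound 2, and compound 4 is estimated at 7000 nM, between 3000 nM and 16000 nM, a step of a 2.3-fold lower number from compound 2 to compound 4 (0.37 log units; beyond the scatter).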

Compound 4, half-maximal inhibitory concentration: 5500 nM
Compound 4: middle estimate off by 1.3-fold (0.10 log units), on the high side; the measured number falls inside the stated range.
By their numbers in this assay, from the lowest: compounds 1, 4 and 3 (each within the scatter of the next); then compound 2.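

In this assay, the diethoxymethyl end of the chain marks the weaker compound, since formyl in its place gives a 3.0-fold lower number from compound 2 to compound 4 (0.47 log units; beyond the scatter). The earlier step showed only that the whole 2,2-diethoxyethyl group raised the number, whereas formylmethyl in place of hydrogen on the saturated chain carbon bound to an aromatic nitrogen gives a 1.4-fold higher number from compound 1 to compound 4 (0.15 log units; within the scatter), so this position accepts a chain ending in formyl with no change beyond the scatter. Nothing available here accounts for the difference between diethoxymethyl and formyl. The compounds shown leave open whether an amine or a carboxylic acid in place of formyl would stay level with compound 1, and whether a longer chain ending in formyl would do the same. They also leave open whether diethoxymethyl would raise the number to the same extent with the shorter linker of compound 3.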